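Swapping cyclopropyl for methyl: what the measured steps suggest

The compounds below may be only part of what the source reports. "The series", "measured", "known", "first", "only" and "open" are said of these compounds alone.

Compound 1 `COc1ncc(-c2ccc3nc(NC(=O)NCC(=O)N4CCCCC4)nn3c2)cc1NS(=O)(=O)c1ccc(F)cc1` gives 130 nM
Compound 2 `COc1ncc(-c2ccc3nc(NC(=O)NC4CC4)nn3c2)cc1NS(=O)(=O)c1ccc(F)cc1` gives 90 nM
Compound 3 `COc1ncc(-c2ccc3nc(NC(=O)NCCN4CCN(C)CC4)nn3c2)cc1NS(=O)(=O)c1ccc(F)cc1` gives 260 nM

Among the compounds with values here, these numbers come from a functional assay on HCT-116 cells (Homo sapiens) for cytotoxicity, read by MTT assay, with a stated time of 72 h (a lower number here means a stronger inhibitor, a higher number a weaker inhibitor), and place compound 2 level with compound 1, as a 1.4-fold lower number from compound 1 to compound 2 (0.16 log units; within the scatter) shows, but clear of compound 3, with a 2.9-fold higher number from compound 2 to compound 3 (0.46 log units; beyond the scatter) as the only step past the usual noise. The remaining pair gives a 2.0-fold higher number from compound 1 to compound 3 (0.30 log units; within the scatter) as its step.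

Compound 4 `CNC(=O)Nc1nc2ccc(-c3cnc(OC)c(NS(=O)(=O)c4ccc(F)cc4)c3)cn2n1` differs from compound 2 in one place methyl in place of cyclopropyl on an amide-type nitrogen and, put simply, carries methyl in place of cyclopropyl on an amide-type nitrogen. All three measured steps alter the group on that same nitrogen, and the largest of them is only modest. Within the data shown here, no measured compound carries methyl there, so this is an extrapolation.

The expected change in this assay is small, and a 1.3-fold higher number from compound 2 to compound 4 (0.12 log units; within the scatter) is the step estimated, with no clear move in either direction. Compound 4 is estimated at 120 nM with an expected range of 50 nM to 300 nM on present evidence.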

Compound 4, half-maximal inhibitory concentration: 180 nM
The estimate for compound 4 lay 1.5-fold (0.18 log units) below the measured number; the range from low to high includes it.
By their numbers in this assay, from the lowest: compounds 2, 1, 4 and 3 (each within the scatter of the next, the first and the last beyond it).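

In this assay, the change from cyclopropyl to methyl on this amide-type nitrogen gives a 2.0-fold higher number from compound 2 to compound 4 (0.30 log units; within the scatter), so the three-membered ring can go without a step beyond the usual scatter. Methyl also stays level with the other two groups on this nitrogen, with a 1.4-fold higher number from compound 1 to compound 4 (0.14 log units; within the scatter) and a 1.4-fold lower number from compound 3 to compound 4 (0.16 log units; within the scatter), which places this small group within the scatter of every group shown. Nothing given here accounts for these numbers.

The compounds shown leave open how a cyclobutyl group, an ethyl group or a chain ending in a carboxylic acid would behave on this nitrogen. They also leave open whether any group there can bring a step beyond the scatter in the stronger direction.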